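Lengthening the chain: from compound 2 to compound 3

The compounds below may be only part of what the source reports. "The series", "measured", "known", "first", "only" and "open" are said of these compounds alone.

Compound 1 `C[C@@H](NC(=O)Nc1ccc(C(C)(C)C)cc1)c1ccccc1` and compound 2 `CCCCCc1ccc(NC(=O)N[C@H](C)c2ccccc2)cc1` share a core and differ only in the group on the aromatic carbon. In an ADME assay on the whole organism with Oryza sativa as the target, tested at 0.1 uM (a lower number here means a stronger effect, a higher number a weaker effect of the compound at the concentration tested), compound 1 gives 100% and compound 2 gives 100%. The one measured step, no change at the digits printed from compound 1 to compound 2 (within the scatter), leaves the read-out unchanged within the scatter, so compound 2 stands level with compound 1 at the digits shown, with no other neighbour to compare against.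

Compound 3 `CCCCCCc1ccc(NC(=O)N[C@H](C)c2ccccc2)cc1` has not yet been measured. It differs from compound 2 by methyl in place of hydrogen on a saturated chain carbon, five bonds along the chain from an aromatic carbon.

Going by the values given here, the only step that bears on this change is the one from compound 1 to compound 2, which also altered the saturated group on the aromatic carbon and produced no shift beyond the scatter. Nothing in the measured pair suggests that one more carbon on that chain would move the read-out, so the expectation is a step of no change at the digits printed from compound 2 to compound 3 (within the scatter), that is, none beyond the scatter. Compound 3 is therefore estimated to give 100% in this assay, within a range from 88% to 104%.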

Compound 3, a percentage reported as activity, at one concentration (the size of the read-out at that concentration, not a potency): 100%
For compound 3 middle estimate and measured number coincide at the digits printed; measured number inside the range.
By their numbers in this assay, from the lowest: compounds 1, 2 and 3 (each within the scatter of the next).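

In this assay, methyl in place of hydrogen on a saturated chain carbon, five bonds along the chain from an aromatic carbon, gives no change at the digits printed from compound 2 to compound 3 (within the scatter) and so gives this position a reading of its own, which the earlier pair could not supply. Exchanging the whole group on the aromatic carbon gives no change at the digits printed from compound 1 to compound 3 (within the scatter) as well, which places tert-butyl, pentyl and hexyl on that carbon within the scatter of one another, so the flat result now holds for three groups rather than two. No supporting information is available to account for this flat read-out.

With all three compounds at one level, the set does not show whether any group at this place can shift the read-out, and a longer chain such as octyl, or an amine or a carboxylic acid at the end of the chain, remains an open case. Also open, going by these compounds, is whether a change elsewhere on the shared core, away from this chain, would move the read-out at all.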